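Same atoms, different arrangement: compound 3 to compound 4

The source may report more compounds than this note shows. Statements on the series, on what has been measured and on what is new or still open speak of the compounds shown alone.

Compound 1 `COc1ccccc1C[C@H]1C(=O)OC[C@@H]1Cc1ccccc1`, compound 2 `CCCCOc1ccccc1C[C@H]1C(=O)OC[C@@H]1Cc1ccccc1` and compound 3 `O=C1OC[C@H](Cc2ccccc2)[C@H]1Cc1ccccc1Cl` share one core and differ only in the group carried on the aromatic ring attached to it. In a functional assay on HL-60 cells (Homo sapiens) for cytotoxicity, read by WST assay, with a stated time of 48 h (on this read-out higher numbers stand for an effect only at larger amounts of compound and lower numbers for an effect already at smaller amounts), compound 1 gives 79000 nM, compound 2 gives 20000 nM and compound 3 gives 37000 nM. Among these three numbers, compound 3 stands second highest: there is a 1.9-fold higher number from compound 2 to compound 3 (0.27 log units; within the scatter), and a 2.1-fold lower number from compound 1 to compound 3 (0.33 log units; beyond the scatter). The remaining step, a 4.0-fold lower number from compound 1 to compound 2 (0.60 log units; beyond the scatter), also exchanges one group for another at a fixed spot.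

Compound 4 `O=C1OC[C@H](Cc2ccccc2)[C@H]1Cc1ccc(Cl)cc1` has the same atoms as compound 3, joined differently: 4-chlorophenyl in place of 2-chlorophenyl on a saturated chain carbon bound to a saturated ring carbon. Going by the values given here, none of the measured steps deals with such a rearrangement; each swaps the identity of a group rather than its arrangement. The data therefore give no direct guide, and in this assay a step within the scatter, or none at all, is expected, as no change at the digits printed from compound 3 to compound 4 (within the scatter). Compound 4 is accordingly estimated at 37000 nM, with a range from 14000 nM to 95000 nM.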

Compound 4, half-maximal effective concentration: 36000 nM
The estimate for compound 4 lay 1.0-fold (0.01 log units) above the measured number; the range from low to high includes it.
By their numbers in this assay, from the lowest: compounds 2, 4 and 3 (each within the scatter of the next); then compound 1.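

The earlier steps shown here each put a different group on the aromatic ring, so they could not show whether the arrangement of one and the same group matters. Here the group stays chlorophenyl, and exchanging 2-chlorophenyl for 4-chlorophenyl on a saturated chain carbon bound to a saturated ring carbon gives a 1.0-fold lower number from compound 3 to compound 4 (0.01 log units; within the scatter) in this assay. For this pair, then, the two arrangements cannot be told apart on this read-out, and nothing available explains that result.

Going by these compounds, whether methoxy or butoxy would also read alike in the two arrangements remains open, since this comparison covers chloro alone. On these data alone, it is also open whether an amine or a carboxylic acid on the aromatic ring would give a number clearly apart from those of compound 3 and compound 4.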